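The compounds below may be only part of what the source reports. "The series", "measured", "known", "first", "only" and "open" are said of these compounds alone.

In a functional assay on HCT-15 cells (Homo sapiens) for inhibition (on this read-out higher numbers stand for weaker inhibition and lower numbers for stronger inhibition), compound 1 (`N[C@H]1CC[C@H](Nc2nc(NCc3cccc(I)c3)c3ncn(C4CCCC4)c3n2)CC1`) gives 2100 nM and compound 2 (`N[C@H]1CC[C@H](Nc2nc(NCC3CC3)c3ncn(C4CCCC4)c3n2)CC1`) gives 3300 nM. Going by the values given here, these two values lie within the usual scatter of each other, so compound 2 stands level with the only other measured compound. Compound 3 (`C[C@H](Nc1nc(N[C@H]2CC[C@H](N)CC2)nc2c1ncn2C1CCCC1)c1ccccc1`) keeps the shared core of compound 2 and changes one group: 1-phenylethyl in place of cyclopropylmethyl on a nitrogen on an aromatic ring. In words, 1-phenylethyl takes the place of cyclopropylmethyl on a nitrogen on an aromatic ring. Among the compounds with values here, one measured step bears on this change, the swap of 3-iodophenyl for cyclopropyl on a saturated chain carbon bound to that kind of nitrogen: a 1.6-fold higher number from compound 1 to compound 2 (0.20 log units; within the scatter). Within the data shown here, no measured compound carries 1-phenylethyl itself, so that exact group remains untested. Given that step of a 1.6-fold higher number from compound 1 to compound 2 (0.20 log units; within the scatter), no change beyond the scatter is expected in this assay. The expected step is a 1.3-fold lower number from compound 2 to compound 3 (0.12 log units; within the scatter). Compound 3 is estimated at 2500 nM, with an expected range from 900 nM to 7000 nM.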

Compound 3, half-maximal inhibitory concentration: 8600 nM
For compound 3 the middle estimate is 3.4-fold (0.54 log units) below the measured one; measured number above the stated range.
By their numbers in this assay, from the lowest: compounds 1 and 2 (each within the scatter of the next); then compound 3.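

In this assay, the group on this nitrogen on an aromatic ring proves able to move the number: a 2.6-fold higher number from compound 2 to compound 3 (0.42 log units; beyond the scatter) and a 4.1-fold higher number from compound 1 to compound 3 (0.61 log units; beyond the scatter) are both steps toward weaker inhibition, and both lie beyond the scatter. Going by these compounds alone, the earlier pair left 3-iodobenzyl and cyclopropylmethyl level with each other, whereas 1-phenylethyl, the only one of the three groups with a defined stereocentre, stands apart from both. No supporting data explain this difference.

With only these three groups at this position, the compounds cannot show whether the weaker inhibition goes with the methyl on the chain carbon, the missing iodine or the stereocentre. Plain benzyl, 2-phenylethyl and the mirror-image form of 1-phenylethyl would each help to separate these features, and their standing remains open.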